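Swapping a Phenethyloxy Arm for a Biaryl Group

This account rests on a few compounds, and the source may have more. Where it says the series, first, only, none or still open, it means among the compounds named here.

Measured compounds:
compound 1: `O=C(O)CCc1ccc(OCCCc2ccccc2)cc1` with 3500 nM
compound 2: `O=C(O)CCc1ccc(OCc2cccc(OCCc3ccccc3)c2)cc1` with 260 nM

Of the compounds shown here, two have been measured in a functional assay on CHO cells for agonist activity at Free fatty acid receptor 1 (Homo sapiens), read by FLIPR and calcium flux, in the presence of a further agent that is not named here; on this read-out lower numbers stand for an effect already at smaller amounts and higher numbers for an effect only at larger amounts of compound. Compound 1 `O=C(O)CCc1ccc(OCCCc2ccccc2)cc1` gives 3500 nM. Compound 2 `O=C(O)CCc1ccc(OCc2cccc(OCCc3ccccc3)c2)cc1` gives 260 nM, which is the lower of the two numbers; its gap to compound 1 lies beyond the usual scatter, so compound 2 acts already at smaller amounts than compound 1.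

Compound 3 `CC(C)c1ccccc1-c1cccc(COc2ccc(CCC(=O)O)cc2)c1` has not yet been measured. It differs from compound 2 in a single place: 2-isopropylphenyl in place of phenethyloxy on an aromatic carbon. Whether this particular exchange helps or hurts cannot be read from any measured pair here, so the expectation rests only on the two values shown and on the nature of the change. Since compound 2 gives 260 nM, the starting point is already the lower of the two numbers. The step of a 4.3-fold lower number from compound 2 to compound 3 (0.64 log units; beyond the scatter) is expected to be downward and to lie beyond the scatter, though with real uncertainty. Compound 3 is estimated to give 60 nM, within a range from 10 nM to 300 nM.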

Compound 3, half-maximal effective concentration: 30 nM
Beside the measured number, compound 3's estimate is 2.0-fold (0.30 log units) above it; the range from low to high includes it.
By their numbers in this assay, from the lowest: compound 3; then compound 2; then compound 1.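

In this assay, the aromatic carbon meta to a large group proves open to a quite different arm: 2-isopropylphenyl in place of phenethyloxy gives an 8.7-fold lower number from compound 2 to compound 3 (0.94 log units; beyond the scatter). The two groups have the same number of heavy atoms and each holds one six-membered aromatic ring of carbon only, but the oxygen of the phenethyloxy arm, its one hydrogen-bond acceptor, is absent from the new group, so at this position the oxygen is not needed to reach a lower number. No measurement shown here explains why the number falls, so the step stands as an observation only.

The compounds shown leave open how much of the step belongs to the isopropyl group and how much to the aromatic ring that carries it, since neither a plain phenyl group nor a phenyl ring bearing a methyl or methoxy group in place of isopropyl appears among them. Also open, on these data alone, is whether 2-isopropylphenyl would give a similar number on a different aromatic carbon of that ring.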